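Swapping chloro for fluoro in compound 3

The source may report more compounds than this note shows. Statements on the series, on what has been measured and on what is new or still open speak of the compounds shown alone.

Three close relatives have been tested so far in a functional assay on MGC-803 cells (Homo sapiens) for antiproliferative activity, read by MTT assay, with a stated time of 72 h (on this read-out higher numbers stand for weaker inhibition and lower numbers for stronger inhibition), on the shared core. Compound 1 (`Cc1ccc(-c2nc(CNc3ccc(C(=O)NO)cc3)n(-c3ccccc3)n2)cc1`) gives > 20000 nM as its reading, which is a limit of the assay and not a number. Compound 2 (`COc1ccc(-c2nc(CNc3ccc(C(=O)NO)cc3)n(-c3ccccc3)n2)cc1`) gives > 20000 nM as its reading, again a limit and not a number. Going by the values given here, compound 3 (`O=C(NO)c1ccc(NCc2nc(-c3ccc(Cl)cc3)nn2-c2ccccc2)cc1`) gives 5970 nM and so holds the only true number of the three.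

Compound 4 (`O=C(NO)c1ccc(NCc2nc(-c3ccc(F)cc3)nn2-c2ccccc2)cc1`) differs from compound 3 at one place: fluoro in place of chloro on an aromatic carbon with fluoro in place of chloro on an aromatic carbon, para to a large group.

The measured steps that bear on this change sit at the same place. Chloro in place of methyl gave an at least 3.3-fold lower number from compound 1 to compound 3 (0.52 log units; beyond the scatter) and chloro in place of methoxy gave an at least 3.3-fold lower number from compound 2 to compound 3 (0.52 log units; beyond the scatter) in the same test. So this place matters, yet no measured step involves fluoro. Chloro is the only group here with a true number, so a modest loss is expected. The estimated change is a 2.2-fold higher number from compound 3 to compound 4 (0.34 log units; beyond the scatter) towards weaker inhibition. A limit reading for compound 4 also stays possible, given the limit of > 20000 nM in this assay, at which 2 of the 3 values shown sit, among its relatives. For compound 4 the estimated value is 13000 nM with 5000 nM to 20000 nM as the expected range.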

Compound 4, half-maximal inhibitory concentration: 8960 nM
Beside the measured number, compound 4's estimate is 1.5-fold (0.16 log units) above it; low and high end bracket the measured number.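

In this assay, going by these compounds alone, fluoro and chloro read alike at this place on the ring, with a 1.5-fold higher number from compound 3 to compound 4 (0.18 log units; within the scatter), and none of the earlier compounds carried fluoro to show this. Fluoro also stands apart from the two non-halogen groups, with an at least 2.2-fold lower number from compound 2 to compound 4 (0.34 log units; beyond the scatter) when it replaces methoxy and an at least 2.2-fold lower number from compound 1 to compound 4 (0.34 log units; beyond the scatter) when it replaces methyl, so both halogen compounds give true numbers where the methyl and methoxy compounds do not. The size of those last two steps is only a lower bound, since the readings of compound 1 and compound 2 are limits and not numbers: the limit of > 20000 nM in this assay, at which 2 of the 4 values shown sit.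

The compounds shown leave open whether this split between halogens and the other groups extends further, for example to bromo, a nitrile, trifluoromethyl or an amine at the same place. They also leave open whether fluoro and chloro would still read alike if placed elsewhere on the shared core.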